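The compounds below may be only part of what the source reports. "The series", "measured", "known", "first", "only" and "open" are said of these compounds alone.

All four compounds share one core, a carbamate bearing a selenocyanate on its aromatic ring, and differ only at the ester end. Compound 1 `COc1ccc(OC(=O)Nc2ccc([Se]C#N)cc2)cc1` carries a methoxy-substituted aromatic ester and gives 44600 nM in a functional assay on PC-3 cells (Homo sapiens) for cytotoxicity, read by MTT assay, with a stated time of 72 h; a lower number here means a stronger inhibitor of growth, a higher number a weaker inhibitor of growth. Compound 2 `C=CCOC(=O)Nc1ccc([Se]C#N)cc1` carries an allyl ester and gives 44700 nM. Compound 3 `Cc1ccc(OC(=O)Nc2ccc([Se]C#N)cc2)cc1` carries a methyl-substituted aromatic ester and gives 32300 nM. Compound 3 sits at the low end of these three numbers, but its gaps to compound 1 and to compound 2 are each within the scatter, so no ranking among them can be claimed.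

Compound 4 `N#C[Se]c1ccc(NC(=O)Oc2ccccc2)cc1` differs from compound 3 by hydrogen in place of methyl on an aromatic carbon, the site being on an aromatic carbon of a six-membered aromatic ring of carbon only, para to a large group. Among the measured compounds shown here, the only measured step at this position, a 1.4-fold lower number from compound 1 to compound 3 (0.14 log units; within the scatter), stayed within the scatter, and even the allyl ester of compound 2 gave a similar number. A step of no size beyond the scatter is therefore expected, a 1.1-fold higher number from compound 3 to compound 4 (0.05 log units; within the scatter). Compound 4 is estimated at 36000 nM, with a range from 18000 nM to 72000 nM.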

Compound 4, concentration for total growth inhibition: 37500 nM
Compound 4: the middle estimate sits 1.0-fold (0.02 log units) below what was measured, and the stated range covers the measured number.
By their numbers in this assay, from the lowest: compounds 3, 4, 1 and 2 (each within the scatter of the next).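

With the methyl gone, the ring of compound 4 carries only hydrogen at this position, and in this assay that change is small (a 1.2-fold higher number from compound 3 to compound 4 (0.06 log units; within the scatter)). Hydrogen in place of methoxy gives a similar result (a 1.2-fold lower number from compound 1 to compound 4 (0.08 log units; within the scatter)), and so does phenyl in place of allyl (a 1.2-fold lower number from compound 2 to compound 4 (0.08 log units; within the scatter)), so hydrogen, methyl and methoxy on this aromatic carbon cannot be told apart here, and neither can the phenyl and allyl esters. No supporting data are available to explain why these numbers stay so close.

The compounds shown leave open whether an amine or a carboxylic acid at this position would move the number beyond the scatter. They also leave open whether a longer chain in place of allyl would do so.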